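The source may report more compounds than this note shows. Statements on the series, on what has been measured and on what is new or still open speak of the compounds shown alone.

The measured compounds:
compound 1 `CC(C)(C)OC(=O)N1CCC[C@H]1C(=O)N1CCC(NS(=O)(=O)c2cc(S(=O)(=O)c3ccccc3)ccc2C(F)(F)F)CC1`: 60 nM;
compound 2 `CC(C)(C)OC(=O)N1C(=O)CC[C@H]1C(=O)N1CCC(NS(=O)(=O)c2cc(S(=O)(=O)c3ccccc3)ccc2C(F)(F)F)CC1`: 90 nM;
compound 3 `O=C([C@@H]1CCCN1C(=O)c1ccncc1)N1CCC(NS(=O)(=O)c2cc(S(=O)(=O)c3ccccc3)ccc2C(F)(F)F)CC1`: 350 nM.

All three were tested in a functional assay on U2OS cells for antagonist activity at proto-oncogene Wnt-3 (Homo sapiens), read by a luciferase reporter, with a stated time of 18 h; on this read-out higher numbers stand for an effect only at larger amounts of compound and lower numbers for an effect already at smaller amounts. Compound 1 has the lowest of the three numbers; compound 2 lies within the usual scatter of it, so the two cannot be ranked, while compound 3 sits clearly further off. Among the compounds with values here, the one step that is resolved, a 5.8-fold higher number from compound 1 to compound 3 (0.77 log units; beyond the scatter), exchanges the group on the carbonyl carbon and leads to an effect only at larger amounts of compound.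

Compound 4 `O=C([C@@H]1CCCN1C(=O)N1CCOCC1)N1CCC(NS(=O)(=O)c2cc(S(=O)(=O)c3ccccc3)ccc2C(F)(F)F)CC1` has not yet been measured in this assay. It differs from compound 1 in a single place: morpholin-4-yl in place of tert-butoxy on a carbonyl carbon. Within the data shown here, the only measured step that bears on this position is the one from compound 1 to compound 3, which was modest and unfavourable. The entering group here is a non-aromatic ring rather than pyridin-4-yl, so a shift in the same direction but of smaller size is expected. For compound 4 the estimate is 180 nM, with a range from 70 nM to 450 nM. This estimate corresponds to an expected 3.0-fold higher number from compound 1 to compound 4 (0.48 log units; beyond the scatter) in this assay.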

Compound 4, half-maximal effective concentration: 280 nM
Compound 4: middle estimate off by 1.6-fold (0.19 log units), on the low side; the measured number falls inside the stated range.
By their numbers in this assay, from the lowest: compounds 1 and 2 (each within the scatter of the next); then compounds 4 and 3 (each within the scatter of the next).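

Putting morpholin-4-yl in place of tert-butoxy on this carbonyl carbon gives a 4.7-fold higher number from compound 1 to compound 4 (0.67 log units; beyond the scatter) in this assay so a non-aromatic ring, like pyridin-4-yl before it, leaves the number clearly further from that of compound 1. The step between the two rings is a 1.3-fold lower number from compound 3 to compound 4 (0.10 log units; within the scatter) and lies within the scatter, so on these numbers the aromatic and the non-aromatic ring cannot be ranked at this position. No measurement offered here explains why either replacement gives the number it does.

Still open, from the compounds shown here alone, is whether a smaller group that keeps an oxygen on the carbonyl carbon, such as ethoxy or isopropoxy, would stay within the scatter of compound 1. Also open, going by these compounds, is what piperidin-1-yl, the same six-membered ring without its oxygen, would give.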